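Imidazolylmethyl on the Amino Nitrogen of Compound 2

The compounds below may be only part of what the source reports. "The series", "measured", "known", "first", "only" and "open" are said of these compounds alone.

Compound 2 `CCCCOc1ccc(-c2nc3ncccn3c2N)cc1` carries a free amino group on the shared core. In a toxicity assay on A549 cells (Homo sapiens) for cytotoxicity, read by luminescence and CellTiter-Glo, with a stated time of 48 h (on this read-out higher numbers stand for lower toxicity in this test and lower numbers for higher toxicity in this test), compound 2 sits at > 100000 nM, which is a limit of the measurement and not a number. Compound 3 `CCCCOc1ccc(-c2nc3ncccn3c2N2C(=O)c3cccc(O)c3C2=O)cc1` likewise sits at > 100000 nM in this assay, again only a limit. Compound 1 `CCCCOc1ccc(-c2nc3ncccn3c2NCC2CCCCC2)cc1` gives 35000 nM in this assay. Within the data shown here, the one measured step, an at least 2.8-fold higher number from compound 1 to compound 2 (0.45 log units; beyond the scatter), shows that taking away the cyclohexylmethyl group raised the number. the limit of > 100000 nM in this assay, at which 2 of the 3 values shown sit, is where compound 2 rests. Compound 4 `CCCCOc1ccc(-c2nc3ncccn3c2NCc2c[nH]cn2)cc1` differs from compound 2 by (1H-imidazol-4-yl)methyl in place of hydrogen on a nitrogen on an aromatic ring. Among the measured compounds shown here, no measured step covers this group; the only step that bears on a substituent on that nitrogen is an at least 2.8-fold higher number from compound 1 to compound 2 (0.45 log units; beyond the scatter), whose size is known only as a lower bound and which concerns a different group. For compound 4 the expected step is therefore a number no higher from compound 2 to compound 4 (the limit leaves the size open), most likely nothing beyond the scatter, with a fair chance that compound 4 returns only a limit. Compound 4 is expected to give 100000 nM in this assay, within 40000 nM to 300000 nM.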

Compound 4, half-maximal cytotoxic concentration: > 100000 nM
Compound 4 was reported as a limit (the forecaster's own chance of this, stated with the estimate: 60%); the middle value lies on the limit itself.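

In this assay the step between compound 2 and compound 4 cannot be read: both values are limits, so adding (1H-imidazol-4-yl)methyl on the nitrogen gives no change with a size. The new information concerns the group carried on the saturated chain carbon, where 1H-imidazol-4-yl in place of cyclohexyl gives an at least 2.8-fold higher number from compound 1 to compound 4 (0.45 log units; beyond the scatter), so a substituent on that nitrogen does not by itself bring the number down to that of compound 1. Compound 4 instead joins the compounds that return only a limit: the limit of > 100000 nM in this assay, at which 3 of the 4 values shown sit.

On these data alone, how far compound 2, compound 3 and compound 4 truly lie from one another stays open, as does the full size of the step to compound 4. Also open, as far as these compounds go, is where a longer alkyl chain, a benzyl group or a carboxylic acid on that nitrogen would fall in this assay.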